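Urea series: trifluoromethyl for chloro on the terminal ring

This account rests on a few compounds, and the source may have more. Where it says the series, first, only, none or still open, it means among the compounds named here.

Compound 1 `COc1cc(-c2nn(-c3cccc(NC(=O)Nc4cc(C(F)(F)F)cc(C(F)(F)F)c4)c3)cc2-c2ccncc2)ccc1Cl` gives 29600 nM in a functional assay on NCI-H23 cells (Homo sapiens) for inhibition, read by sulforhodamine B assay, with a stated time of 48 h; a higher number here means that more compound is tolerated, a lower number that less compound is tolerated. Compound 2 `COc1cc(-c2nn(-c3cccc(NC(=O)Nc4ccc(Cl)c(Cl)c4)c3)cc2-c2ccncc2)ccc1Cl` reaches only the assay limit of > 50000 nM in this assay. Compound 3 `O=C(Nc1cccc(-n2cc(-c3ccncc3)c(-c3ccc(Cl)c(O)c3)n2)c1)Nc1ccc(Cl)c(Cl)c1` likewise stops at the limit of > 32500 nM in this assay.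

Compound 2 thus stands at a limit, as does compound 3; the step that the two limits leave unreadable from compound 2 to compound 3 cannot be sized, and only compound 1 gives a number. Compound 4 `COc1cc(-c2nn(-c3cccc(NC(=O)Nc4ccc(Cl)c(C(F)(F)F)c4)c3)cc2-c2ccncc2)ccc1Cl` differs from compound 2 by trifluoromethyl in place of chloro on an aromatic carbon. Among the measured compounds shown here, no measured step bears on this change, and compound 1 shows only that a bis(trifluoromethyl) analogue yields a number. Compound 4 is therefore expected near the limit in this assay, with the step of an at least 1.2-fold lower number from compound 2 to compound 4 (0.09 log units; that floor lies within the scatter) estimated within the scatter. The estimate for compound 4 is 40000 nM, from 15000 nM to 100000 nM.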

Compound 4, concentration lethal to 50% of the cells: > 32500 nM
Compound 4: only a limit was reported (the forecaster's own chance of this, stated with the estimate: 50%); the middle value is on the limit's open side.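

Compound 4 gives only a limit, > 32500 nM, in this assay. Among the compounds shown here, compound 2 also stands at a limit, so no step between compound 2 and compound 4 can be read. From the compounds shown here alone, the size of any change from trifluoromethyl in place of chloro remains open.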